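The source may report more compounds than this note shows. Statements on the series, on what has been measured and on what is new or still open speak of the compounds shown alone.

Compound 2 `FC(F)(F)c1ccc(Nc2ccc(N3CC4CC(C3)N4)cn2)cc1` sits in the middle of the three measured compounds: in an assay on cell membranes for displacement of a labelled ligand from Neuronal acetylcholine receptor; alpha4/beta2 (Rattus norvegicus) (on this read-out lower numbers stand for stronger inhibition and higher numbers for weaker inhibition), compound 2 gives 0.569 nM, whereas compound 1 `Clc1ccc(Nc2ccc(N3CC4CC(C3)N4)cn2)cc1` gives 2.49 nM and compound 3 `Clc1cccc(Nc2cncc(N3CC4CC(C3)N4)c2)c1` gives 0.124 nM. Compound 4 `COc1ccc(Nc2ccc(N3CC4CC(C3)N4)cn2)cc1` differs from compound 2 by methoxy in place of trifluoromethyl on an aromatic carbon. Among the measured compounds shown here, only one measured step changes the same group: a 4.4-fold lower number from compound 1 to compound 2 (0.64 log units; beyond the scatter). For the measured compounds named here, no measured pair swaps trifluoromethyl for methoxy, so the direction of the new step rests on that single change and its modest size. A modest rise in the number is expected for compound 4, a 4.4-fold higher number from compound 2 to compound 4 (0.64 log units; beyond the scatter). In this assay compound 4 is therefore estimated at 2.5 nM, with a likely range from 0.7 nM to 9 nM.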

Compound 4, inhibition constant: 7.3 nM
The estimate for compound 4 lay 2.9-fold (0.47 log units) below the measured number; the measured number falls inside the stated range.
By their numbers in this assay, from the lowest: compound 3; then compound 2; then compound 1; then compound 4.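

Methoxy on this aromatic carbon, para to a large group, gives a 13-fold higher number from compound 2 to compound 4 (1.11 log units; beyond the scatter) and also a 2.9-fold higher number from compound 1 to compound 4 (0.47 log units; beyond the scatter) as a further rise, so it stands apart from both chloro and trifluoromethyl. The three groups at this place now fall in one order, from trifluoromethyl through chloro to methoxy, with each step beyond the scatter. Nothing available explains this order.

Open, on these data alone, is where an amine, a hydroxyl group or a longer chain such as ethoxy would fall in that order. Also open, as far as these compounds go, is whether the same order holds on the core of compound 3.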